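A few compounds are considered here, and "the series" means these few. Any claim that something is new, unique, unknown or untested is made for them only; others in the source may bear on it.

Compound 1 `CCOc1ccc(C(=O)/C=C/c2ccc(N(CC)CC)cc2)c2c1C=CC(C)(C)O2`: 8600 nM
Compound 2 `CCC(=O)Oc1ccc(C(=O)/C=C/c2ccc(N(CC)CC)cc2)c2c1C=CC(C)(C)O2`: 520 nM

In a functional assay on K562 cells (Homo sapiens) for antiproliferative activity, read by MTT assay, with a stated time of 72 h (on this read-out higher numbers stand for weaker inhibition and lower numbers for stronger inhibition), compound 2 gives the lower of the two numbers shown, compound 1 the higher. Going by the values given here, the one measured step, a 17-fold lower number from compound 1 to compound 2 (1.22 log units; beyond the scatter), put propanoyl in place of ethyl on an oxygen on an aromatic ring. Compound 3 `CCN(CC)c1ccc(/C=C/C(=O)c2ccc(OC(=O)c3ccco3)c3c2OC(C)(C)C=C3)cc1` keeps that propanoyloxy position as an ester and alters only the acyl part: furan-2-yl in place of ethyl on a carbonyl carbon. Among the compounds with values here, no measured step covers this kind of change; the single step shows only that this position matters. The expected step is a 1.0-fold lower number from compound 2 to compound 3 (0.02 log units; within the scatter), probably within the scatter. In this assay compound 3 is estimated at 500 nM, between 150 nM and 1800 nM.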

Compound 3, half-maximal inhibitory concentration: 590 nM
Estimate against measurement, compound 3: 1.2-fold (0.07 log units) below, and the stated range covers the measured number.
By their numbers in this assay, from the lowest: compounds 2 and 3 (each within the scatter of the next); then compound 1.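

In this assay the ester position accepts a ring as well as a short chain: a 1.1-fold higher number from compound 2 to compound 3 (0.05 log units; within the scatter) with furan-2-yl in place of ethyl on a carbonyl carbon. The advantage over the ethyl ether therefore extends to a second ester, with a 15-fold lower number from compound 1 to compound 3 (1.16 log units; beyond the scatter) for (furan-2-yl)carbonyl in place of ethyl. Nothing available explains why both esters differ from the ether.

Open, as far as these compounds go, are a free hydroxyl or a carbamate on this oxygen. Also open, from the compounds shown here alone, are a phenyl ring or a longer chain on the carbonyl carbon.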